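Ortho Fluorine in Place of Para Methyl on a Benzylidene Arm

The compounds below may be only part of what the source reports. "The series", "measured", "known", "first", "only" and "open" are said of these compounds alone.

The measured compounds:
- compound 1, `C=CCn1c(=O)/c(=C\c2cccc(Cl)c2)[nH]c(=O)/c1=C\c1ccccc1OC`, 5200 nM in a functional assay on MCF7 cells (Homo sapiens) for cytotoxicity, read by CCK-8 assay, with a stated time of 72 h; on this read-out higher numbers stand for weaker inhibition and lower numbers for stronger inhibition
- compound 2, `C=CCn1c(=O)/c(=C\c2ccccc2C(F)(F)F)[nH]c(=O)/c1=C\c1ccccc1OC`, 6500 nM in this assay
- compound 3, `C=CCn1c(=O)/c(=C\c2ccc(C)cc2)[nH]c(=O)/c1=C\c1ccccc1OC`, reported only as "not active" (no number reported) in this assay, with no number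

Compound 3 therefore stands outside the numbers shown: where compound 1 and compound 2 give measured half-maximal inhibitory concentrations, compound 3 has none. Compound 4, `C=CCn1c(=O)/c(=C\c2ccccc2F)[nH]c(=O)/c1=C\c1ccccc1OC`, differs from compound 3 by 2-fluorophenyl in place of 4-methylphenyl on a double-bonded chain carbon bound to an aromatic carbon. Going by the values given here, the one measured step at this same position, a 1.3-fold higher number from compound 1 to compound 2 (0.10 log units; within the scatter), was within the scatter, so the two numbered compounds give no sign that changing the group there moves the read-out much. Among the compounds with values here, no step from compound 3 can be sized, as compound 3 has no number. Compound 4 is expected to come in near compound 1 and compound 2, estimated at 8000 nM, with a range of 3000 nM to 30000 nM.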

Compound 4, half-maximal inhibitory concentration: 23000 nM
For compound 4 the middle estimate is 2.9-fold (0.46 log units) below the measured one, and the stated range covers the measured number.
By their numbers in this assay, from the lowest: compounds 1 and 2 (each within the scatter of the next); then compound 4.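

In this assay, going by these compounds alone, the 2-fluorophenyl group gives the first steps at this position that lie beyond the scatter, both modest (a 3.5-fold higher number from compound 2 to compound 4 (0.55 log units; beyond the scatter); a 4.4-fold higher number from compound 1 to compound 4 (0.65 log units; beyond the scatter)). The group on this double-bonded chain carbon can therefore shift the read-out, which the earlier pair did not show, though any step from compound 3 cannot be read. No measurement here accounts for the shift. The compounds shown leave open whether an amine or a carboxylic acid on this phenyl ring would shift the number further.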